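Resorcinol-isoxazole amides: ester for aminomethyl substituent

The source may hold more compounds than are shown below. What is called first, only, known or untested is meant among the compounds shown, and "the series" means these compounds.

Measured compounds:
- compound 1 `CCNC(=O)c1noc(-c2cc(C(C)C)c(O)cc2O)c1-c1cc(CNC)no1`: "not determined" (no result reported)
- compound 2 `CCCNCc1cc(-c2c(C(=O)NCC)noc2-c2cc(C(C)C)c(O)cc2O)on1`: "not determined" (no result reported)
- compound 3 `CCNC(=O)c1noc(-c2cc(C(C)C)c(O)cc2O)c1-c1cc(CN2CCCCC2)no1`: 62 nM

Notes on the series. The shared core carries a 1,2-oxazol-5-yl group whose substituent varies across the three measured compounds. Compound 1 has no number in a functional assay on A2780 cells (Homo sapiens) for inhibition; a lower number here means a stronger inhibitor, a higher number a weaker inhibitor; the entry reads "not determined" (no result reported). Compound 2 likewise has no number, with "not determined" (no result reported). Among the compounds with values here, only compound 3 gives a value, 62 nM, so there is no anchor for compound 1 itself and no measured step to relate it to.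

The unmeasured compound 4 `CCNC(=O)c1noc(-c2cc(C(C)C)c(O)cc2O)c1-c1cc(C(=O)OCC)no1` differs from compound 1 in one place: ethoxycarbonyl in place of (methylamino)methyl on an aromatic carbon. Without a number for compound 1, the step cannot be sized from data; in this assay the expectation is a moderate move toward weaker inhibition relative to compound 3, which carries a different amine-bearing substituent, though this is uncertain. Compound 4 is expected to give about 150 nM, with a range from 30 nM to 800 nM.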

Compound 4, half-maximal inhibitory concentration: 9000 nM
Beside the measured number, compound 4's estimate is 60-fold (1.78 log units) below it, and the stated range ends below it.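

In this assay, within the data shown here, the substituent on this aromatic carbon has a large bearing on the read-out: ethoxycarbonyl in place of (piperidin-1-yl)methyl gives a 150-fold higher number from compound 3 to compound 4 (2.16 log units; beyond the scatter) and this is the first measured step at this position, with the amine-bearing compound 3 the stronger inhibitor of the pair. Steps involving compound 1 or compound 2 cannot be read, so the comparison rests on a single pair. No measurement shown accounts for the size of this step.

Going by these compounds, it remains open whether the ester itself or the absence of the amine governs the difference, and a carboxylic acid or a primary amide on this carbon would help separate the two. On these data alone, how far the amine can vary also stays open, for example with a (morpholin-4-yl)methyl or (dimethylamino)methyl group.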